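Nitro for trifluoromethyl on a second chromane urea core

A few compounds are considered here, and "the series" means these few. Any claim that something is new, unique, unknown or untested is made for them only; others in the source may bear on it.

Three diaryl ureas have been measured in a functional assay on A2780 cells (Homo sapiens) for inhibition, with a stated time of 72 h, tested at 10 uM; a lower number here means less inhibition of growth, a higher number more inhibition of growth at the concentration tested. Compound 3 `CC1(C)CCOc2ccc(NC(=O)Nc3ccc(C(F)(F)F)cc3)cc21` gives 47%. Compound 1 `CC1(C)CCOc2ccc(NC(=O)Nc3ccc([N+](=O)[O-])cc3)cc21` differs from compound 3 only by nitro in place of trifluoromethyl on an aromatic carbon. Compound 1 gives 74%, so that the step of a number 27 percentage points higher from compound 3 to compound 1 (beyond the scatter) is a clear gain. Compound 2 `CCC1(CC)CC(C)(C)c2cc(NC(=O)Nc3ccc(C(F)(F)F)cc3)ccc2O1`, built on a different core, gives 92.4% and stands highest of the three; the difference between its core and that of compound 3 is not broken down here.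

Compound 4 `CCC1(CC)CC(C)(C)c2cc(NC(=O)Nc3ccc([N+](=O)[O-])cc3)ccc2O1` has not yet been measured. It differs from compound 2 by nitro in place of trifluoromethyl on an aromatic carbon, which is the same change that turns compound 3 into compound 1, at the same place on the ring; among these compounds it occurs twice in all.

On the earlier step alone one would expect a gain of the size of a number 27 percentage points higher from compound 3 to compound 1 (beyond the scatter). The read-out, however, is percent growth inhibition at a single concentration, and compound 2 already sits close to full inhibition, so the room left is small. The step from compound 2 is therefore expected to be only a number 3.6 percentage points higher from compound 2 to compound 4 (within the scatter) because compound 2 already gives 92.4%. Compound 4 is estimated to reach 96% in this assay, with a likely span from 88% to 100%.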

Compound 4, percent growth inhibition at one concentration: 93.2%
Compound 4: the middle estimate sits 2.8 percentage points above what was measured; the measured number falls inside the stated range.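

In this assay, nitro in place of trifluoromethyl on the core of compound 2 gives a step of a number 0.8 percentage points higher from compound 2 to compound 4 (within the scatter), so no gain can be read on this core. Set beside the earlier step, the change does not carry over with its size from one core to the other: the same change on two cores in this assay, a number 27 percentage points higher (beyond the scatter) from compound 3 to compound 1 and a number 0.8 percentage points higher (within the scatter) from compound 2 to compound 4, 26.2 percentage points apart, beyond the scatter of two such steps. Within the data shown here, this does not show that nitro and trifluoromethyl are equivalent on the core of compound 2, or that this core alters the effect of the change, since compound 2 gives 92.4% and compound 4 gives 93.2%, both close to full inhibition on a read-out taken at a single concentration, and with only two cores the pair of steps supports no rule for the series.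

The compounds shown leave open whether compound 2 and compound 4 would separate at lower concentrations, where the read-out is further from full inhibition. They also leave open how a nitrile, a chlorine or an amine in the place of nitro would behave on either core, and so whether the gain from compound 3 to compound 1 is particular to nitro.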